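Adding a Second Chloro: Expected Effect on Growth Inhibition

This account rests on a few compounds, and the source may have more. Where it says the series, first, only, none or still open, it means among the compounds named here.

Measured compounds in a functional assay on MDA-MB-231 cells (Homo sapiens) for cytotoxicity, read by sulforhodamine B assay, with a stated time of 48 h; a higher number here means a weaker inhibitor of growth, a lower number a stronger inhibitor of growth:
compound 1, `ClCc1ccc(Cn2cnc3c(Cl)ncnc32)cc1`, gives 1770 nM
compound 2, `ClCc1cccc(Cn2cnc3ncnc(Cl)c32)c1`, gives 1730 nM
compound 3, `ClCc1ccc(Cn2cnc3c(Cl)nc(Cl)nc32)cc1`, gives 1820 nM

Compound 1 and compound 2 share the same atoms joined differently; the difference between the two cores is not broken down here. Their values in this assay lie within the scatter of each other, as does the value of compound 3, so no ordering among the three can be read from these numbers.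

Compound 3 arises from compound 1 by the change (chloro in place of hydrogen on an aromatic carbon). That change produced a 1.0-fold higher number from compound 1 to compound 3 (0.01 log units; within the scatter), a step within the scatter.

Compound 4, `ClCc1cccc(Cn2cnc3nc(Cl)nc(Cl)c32)c1`, has not yet been measured. It arises from compound 2 by the change (chloro in place of hydrogen on an aromatic carbon). The place of this change is described in the same words as for the change from compound 1 to compound 3, so it is the same change made on the other core.

The expectation for compound 4 in this assay rests on this single earlier instance: the step from compound 2 to compound 4 is expected to be about a 1.0-fold higher number from compound 2 to compound 4 (0.01 log units; within the scatter), because the same change gave a 1.0-fold higher number from compound 1 to compound 3 (0.01 log units; within the scatter). Compound 4 is therefore estimated at 1780 nM, with a likely range from 900 nM to 3600 nM. The basis is one pair only, so the range is kept wide.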

Compound 4, concentration for 50% growth inhibition: 460 nM
Estimate against measurement, compound 4: 3.9-fold (0.59 log units) above, and the stated range ends above it.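

In this assay, replacing hydrogen with chloro on an aromatic carbon, between two ring nitrogen atoms, gave a 3.8-fold lower number from compound 2 to compound 4 (0.58 log units; beyond the scatter), so on the core of compound 2 the change goes with a stronger inhibitor of growth. On the core of compound 1 the same change left no readable difference, and the two instances do not agree in size: the same change on two cores in this assay, a 1.0-fold higher number (0.01 log units; within the scatter) from compound 1 to compound 3 and a 3.8-fold lower number (0.58 log units; beyond the scatter) from compound 2 to compound 4, 3.9-fold (0.59 log units) apart, beyond the scatter of two such steps

This shows that, for these two pairs, the effect of the change did not carry from one core to the other, so a step read on one core could not be taken over unchanged to the other; it does not show why the cores differ, nor does it give a rule for any further core, since it rests on two pairs in a single assay.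

The compounds shown leave open whether an amine or a methoxy group in the same place, between two ring nitrogen atoms, would follow chloro on either core. They also leave open how the two cores would compare if a hydroxymethyl group stood in place of the chloromethyl group.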